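A tert-Butylphenyl Triazole Ester in a Series Without Cytotoxicity

The compounds below may be only part of what the source reports. "The series", "measured", "known", "first", "only" and "open" are said of these compounds alone.

Compound 1 `C/C(=C\CC/C(C)=C/CC[C@@H]1[C@@]2(C)CCC(=O)C(C)(C)[C@H]2CC[C@@]1(C)O)CC/C=C(\C)C(=O)OCc1cn(-c2ccc(F)c(Cl)c2)nn1`: > 150000 nM
Compound 2 `C/C(=C\CC/C(C)=C/CC[C@@H]1[C@@]2(C)CCC(=O)C(C)(C)[C@H]2CC[C@@]1(C)O)CC/C=C(\C)C(=O)O`: > 150000 nM
Compound 3 `C/C(=C\CC/C(C)=C/CC[C@@H]1[C@@]2(C)CCC(=O)C(C)(C)[C@H]2CC[C@@]1(C)O)CC/C=C(\C)C(=O)OCc1cn(-c2ccc(C)cc2)nn1`: > 150000 nM

In an ADME assay on L132 cells (Homo sapiens) for cytotoxicity, read by MTT assay, with a stated time of 48 h (on this read-out lower numbers stand for stronger inhibition and higher numbers for weaker inhibition), compound 1 gives only a limit of the assay, > 150000 nM. Compound 2 likewise gives a limit, > 150000 nM. Compound 3 gives a limit as well, > 150000 nM. Among the measured compounds shown here, the single measured step, a step that the two limits leave unreadable from compound 1 to compound 3, cannot be sized for that reason. Compound 4 `C/C(=C\CC/C(C)=C/CC[C@@H]1[C@@]2(C)CCC(=O)C(C)(C)[C@H]2CC[C@@]1(C)O)CC/C=C(\C)C(=O)OCc1cn(-c2ccc(C(C)(C)C)cc2)nn1` differs from compound 1 in one place: 4-(tert-butyl)phenyl in place of 3-chloro-4-fluorophenyl on an aromatic nitrogen. For the measured compounds named here, no measured step gives a readable size for a change at this position; what the numbers offer is the limit of > 150000 nM in this assay, at which 3 of the 3 values shown sit. Resting on (the limit of > 150000 nM in this assay, at which 3 of the 3 values shown sit), compound 4 is expected to sit at or beyond that same limit, with a step that the limit leaves unreadable from compound 1 to compound 4 that is not expected to show beyond the scatter. The estimate for compound 4 is 200000 nM, ranging from 100000 nM to 400000 nM.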

Compound 4, half-maximal inhibitory concentration: 65800 nM
For compound 4 the middle estimate is 3.0-fold (0.48 log units) above the measured one; measured number below the stated range.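

In this assay, the group on the aromatic nitrogen proves able to move the read-out: 4-(tert-butyl)phenyl in place of 3-chloro-4-fluorophenyl gives an at least 2.2-fold lower number from compound 1 to compound 4 (0.35 log units; beyond the scatter), and tert-butyl in place of methyl on the aromatic carbon gives an at least 2.2-fold lower number from compound 3 to compound 4 (0.35 log units; beyond the scatter). Going by these compounds, each step starts from a limit, so its true size remains unknown. Compound 4 alone gives a number rather than a limit: the limit of > 150000 nM in this assay, at which 3 of the 4 values shown sit.

On these data alone, whether an isopropyl group or an amine in the same place would also lower the number remains open. So does whether a tert-butyl group needs the phenyl ring to keep no chlorine or fluorine.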